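Restoring a methoxy group on the thiazolidinedione-benzimidazole series

The source may report more compounds than this note shows. Statements on the series, on what has been measured and on what is new or still open speak of the compounds shown alone.

Compound 1 `COc1cc(OC)c(-c2nc3cc(/C=C4\SC(=O)NC4=O)ccc3[nH]2)cc1OC`: 24500 nM
Compound 2 `COc1cc(-c2nc3cc(/C=C4\SC(=O)N(CC(=O)N5CCOCC5)C4=O)ccc3[nH]2)cc(OC)c1OC`: 14900 nM
Compound 3 `COc1ccc(-c2nc3cc(/C=C4\SC(=O)N(CC(=O)N5CCOCC5)C4=O)ccc3[nH]2)cc1OC`: > 50000 nM

Compound 3 sits at the limit of a functional assay on MDA-MB-231 cells (Homo sapiens) for inhibition, read by MTT assay, with a stated time of 48 h; on this read-out higher numbers stand for weaker inhibition and lower numbers for stronger inhibition: its value is a limit of the assay and not a number (the limit of > 50000 nM in this assay, at which 1 of the 3 values shown sits). Compound 2 gives 14900 nM and compound 1 gives 24500 nM in this assay, so compound 3 is the weakest of the three measured compounds.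

The unmeasured compound 4 `COc1cc(OC)c(-c2nc3cc(/C=C4\SC(=O)N(CC(=O)N5CCOCC5)C4=O)ccc3[nH]2)cc1OC` differs from compound 3 by methoxy in place of hydrogen on an aromatic carbon; in words, methoxy in place of hydrogen on an aromatic carbon, taking the ring from 3,4-dimethoxyphenyl to 2,4,5-trimethoxyphenyl. Compound 4 thereby carries the same 2,4,5-trimethoxyphenyl as compound 1.

Among the measured compounds shown here, the only measured step that bears on this change runs the other way: an at least 3.3-fold higher number from compound 2 to compound 3 (0.52 log units; beyond the scatter), where a methoxy was removed from a different aromatic carbon. Adding a methoxy back to compound 3 is therefore expected to lower the number, with the value of compound 1 as a guide to where a 2,4,5-trimethoxyphenyl compound may settle. The expected step is an at least 2.5-fold lower number from compound 3 to compound 4 (0.39 log units; beyond the scatter).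

Compound 4 is estimated at 20000 nM in this assay, within a range from 8000 nM to 55000 nM.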

Compound 4, half-maximal inhibitory concentration: 21300 nM
Beside the measured number, compound 4's estimate is 1.1-fold (0.03 log units) below it; the range from low to high includes it.
By their numbers in this assay, from the lowest: compounds 2, 4 and 1 (each within the scatter of the next). At a limit, above all of these: compound 3.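

In this assay, a methoxy placed ortho to a large group, meta to one methoxy group and para to another, gives an at least 2.3-fold lower number from compound 3 to compound 4 (0.37 log units; beyond the scatter), so this position can carry the third methoxy just as the position used in compound 2 can. The placement of that third methoxy makes no readable difference, with a 1.4-fold higher number from compound 2 to compound 4 (0.16 log units; within the scatter) between the 3,4,5-trimethoxyphenyl and 2,4,5-trimethoxyphenyl rings, and with the same ring the ((morpholin-4-yl)carbonyl)methyl group on the ring nitrogen also makes no readable difference, with a 1.2-fold lower number from compound 1 to compound 4 (0.06 log units; within the scatter) on adding it. The step from compound 3 has a minimum size only, since the entry for compound 3 is a limit of the assay and not a number: the limit of > 50000 nM in this assay, at which 1 of the 4 values shown sits.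

The compounds shown leave open whether a hydroxy group, a fluorine atom or an amine at this position would serve as the methoxy does. They also leave open whether a carboxylic acid or a longer chain in place of the ((morpholin-4-yl)carbonyl)methyl group on the nitrogen would shift the number in this assay at all.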